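Notes on compound 3: combining two aryl substituents

A few compounds are considered here, and "the series" means these few. Any claim that something is new, unique, unknown or untested is made for them only; others in the source may bear on it.

Measured so far:
compound 1 `CC1=C(/C=C/C(=O)/C=C/c2ccc(C(F)(F)F)cc2)C(C)(C)CCC1O`: 3000 nM
compound 2 `CC1=C(/C=C/C(=O)/C=C/c2ccccc2F)C(C)(C)CCC1O`: 2900 nM

In a functional assay on LNCaP cells (Homo sapiens) for cytotoxicity, read by MTT assay, with a stated time of 72 h (a higher number here means a weaker inhibitor, a lower number a stronger inhibitor), compound 2 gives the lower of the two numbers, but compound 1 sits so close that both fall within the usual scatter, so no order between them can be claimed. Compound 3 `CC1=C(/C=C/C(=O)/C=C/c2ccc(C(F)(F)F)cc2F)C(C)(C)CCC1O` arises from compound 2 by trifluoromethyl in place of hydrogen on an aromatic carbon. Among the compounds with values here, no measured pair shows this change in isolation; compound 1, which carries the same trifluoromethyl group without the fluoro group, gives 3000 nM in this assay. A step beyond the scatter is therefore not expected in either direction. Compound 3 is estimated at 2500 nM, within 1000 nM to 6500 nM. The expected step of a 1.2-fold lower number from compound 2 to compound 3 (0.06 log units; within the scatter) is small.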

Compound 3, half-maximal inhibitory concentration: 2600 nM
Beside the measured number, compound 3's estimate is 1.0-fold (0.02 log units) below it; the measured number falls inside the stated range.
By their numbers in this assay, from the lowest: compounds 3, 2 and 1 (each within the scatter of the next).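

In this assay, trifluoromethyl in place of hydrogen gives a 1.1-fold lower number from compound 2 to compound 3 (0.05 log units; within the scatter), and fluoro in place of hydrogen gives a 1.2-fold lower number from compound 1 to compound 3 (0.06 log units; within the scatter), so neither step can be read as a change. With both groups on the same aromatic ring, the number therefore stays within the scatter of each single-substituent compound. Nothing measured here explains this flat result. The compounds shown leave open whether an amine or a carboxylic acid on that aromatic carbon would move the number beyond the scatter. They also do not show whether any aryl substituent matters, since no unsubstituted ring appears among them.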